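Changing the halogenated ring of an enone series: compound 3

This account rests on a few compounds, and the source may have more. Where it says the series, first, only, none or still open, it means among the compounds named here.

The series shares the core of compound 1 `O=C(COc1ccc(C(=O)/C=C/c2cccc([N+](=O)[O-])c2)cc1)N[C@H]1CCOC1=O`, in which a chalcone-like enone is joined through an ether link to a lactone-bearing amide. In a functional assay on MCF7 cells (Homo sapiens) for antiproliferative activity, read by MTT assay, with a stated time of 72 h (a lower number here means a stronger inhibitor, a higher number a weaker inhibitor), compound 1 gives only a limit, > 64000 nM. Compound 2 `O=C(COc1ccc(C(=O)/C=C/c2cccc(F)c2)cc1)N[C@H]1CCOC1=O` carries a fluoro in place of the nitro on an aromatic carbon. In this assay compound 2 likewise gives only a limit, > 64000 nM. The step that the two limits leave unreadable from compound 1 to compound 2 therefore cannot be read, and compound 2 stands at the limit rather than at a number, as the limit of > 64000 nM in this assay, at which 2 of the 2 values shown sit, records. Compound 3 `O=C(COc1ccc(C(=O)/C=C/c2ccc(Br)cc2)cc1)N[C@H]1CCOC1=O` differs from compound 2 by 4-bromophenyl in place of 3-fluorophenyl on a double-bonded chain carbon bound to a double-bonded chain carbon. Going by the values given here, no measured step bears on this change, because both values shown sit at the limit of > 64000 nM in this assay, at which 2 of the 2 values shown sit. He expects compound 3 to remain at or near the same limit, with the estimated step that the limit leaves unreadable from compound 2 to compound 3 not readable beyond the scatter. His estimate for compound 3 in this assay is 100000 nM, within 30000 nM to 400000 nM.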

Compound 3, half-maximal inhibitory concentration: > 64000 nM
Compound 3: a limit, no number; the forecaster's own chance of this, stated with the estimate: 80%; the middle value lies beyond the limit too.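

Going by these compounds alone, no step among compound 1, compound 2 and compound 3 can be read, since all three stand only at a limit: the limit of > 64000 nM in this assay, at which 3 of the 3 values shown sit. On these data alone, what stays open is whether 3-nitrophenyl, 3-fluorophenyl and 4-bromophenyl differ at all in this assay once a number can be read.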